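Swapping a Cyclopentyl Amide for a Pyridin-2-yl Amide

This account rests on a few compounds, and the source may have more. Where it says the series, first, only, none or still open, it means among the compounds named here.

Compound 1: `C#CCn1cc(C(=O)NC(CC(=O)Nc2ccccn2)c2ccccc2)c(=O)c2cc(F)c(Cl)nc21` — 2100 nM
Compound 2: `C#CCn1cc(C(=O)NC(CC(=O)NC2CCCC2)c2ccccc2)c(=O)c2ccc(Cl)nc21` — > 10000 nM

Of the compounds shown here, two have been tested in a functional assay on DU-145 cells (Homo sapiens) for cytotoxicity, read by MTT assay, with a stated time of 72 h; a lower number here means a stronger inhibitor, a higher number a weaker inhibitor. Compound 1 gives 2100 nM, a measurable number. Compound 2 returns only a limit, > 10000 nM, so no exact potency is known for it. Going by the values given here, compound 2 therefore stands at the weak end of what this assay can report, at the limit of > 10000 nM in this assay, at which 1 of the 2 values shown sits, while compound 1 is the only one with a real value. The two share a core and the phenyl-bearing chain, but differ in two places at once, so their values can be compared only as they stand, without a single attributable change.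

Compound 3, `C#CCn1cc(C(=O)NC(CC(=O)Nc2ccccn2)c2ccccc2)c(=O)c2ccc(Cl)nc21`, has not been measured. It differs from compound 2 in one place: pyridin-2-yl in place of cyclopentyl on an amide-type nitrogen. This change brings compound 3 closer in build to compound 1, sharing its amide end, while keeping the core of compound 2.

Given that compound 1 gives 2100 nM with the same amide end, the step is expected to move toward stronger inhibition, an at least 2.5-fold lower number from compound 2 to compound 3 (0.39 log units; beyond the scatter). As far as these compounds go, compound 2 returns only a limit, so the true size of this expected step stays open. Compound 3 is expected to give about 4000 nM, plausibly between 1500 nM and 12000 nM.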

Compound 3, half-maximal inhibitory concentration: 4900 nM
The estimate for compound 3 lay 1.2-fold (0.09 log units) below the measured number; the measured number falls inside the stated range.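

Compound 3 lets the two differences between compound 1 and compound 2 be looked at one at a time in this assay, and the first is now clear: hydrogen in place of fluoro on an aromatic carbon gives a 2.3-fold higher number from compound 1 to compound 3 (0.37 log units; beyond the scatter), so within this pair the fluoro-bearing compound 1 is the stronger inhibitor. The second difference, pyridin-2-yl in place of cyclopentyl on an amide-type nitrogen, gives an at least 2.0-fold lower number from compound 2 to compound 3 (0.30 log units; that floor lies within the scatter), which is only a floor and does not by itself show a change larger than ordinary repeat variation. Compound 2 gives only a limit of the assay, so the real size of that step stays unknown: the limit of > 10000 nM in this assay, at which 1 of the 3 values shown sits.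

The compounds shown compare only fluoro with hydrogen on that aromatic carbon, so they leave open how a methyl or methoxy group there would read. They also cannot separate the ring nitrogen of pyridin-2-yl from the aromatic ring itself, a question that a plain phenyl group on the same amide-type nitrogen would address.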